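A few compounds are considered here, and "the series" means these few. Any claim that something is new, unique, unknown or untested is made for them only; others in the source may bear on it.

Compound 1 `CCCCCCCC#Cc1cc2cn(COCCO)c(=O)nc2o1` gives, in a functional assay on HEL cells (Homo sapiens) (a higher number here means that more compound is tolerated, a lower number that less compound is tolerated), a limit of > 50000 nM.
Compound 2 `CCCCCCc1cc2cn(COCCO)c(O)nc-2n1` gives in this assay a limit of > 200000 nM.
Compound 3 `O=c1nc2occc2cn1COCCO` gives in this assay a limit of > 200000 nM.

None of the three measured compounds gives a number in this assay; each stands at a limit. Compound 2 sits at the limit of > 200000 nM in this assay, at which 2 of the 3 values shown sit, and compound 3 shares that limit. Compound 1 sits at the limit of > 50000 nM in this assay, at which 1 of the 3 values shown sits. So compound 2 is, on the numbers shown, one of two compounds for which the assay reached its upper limit without a readable value, and no measured step between any two of these compounds exists.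

Compound 4 `CCCCCCCCCCCc1cc2cn(COCCO)c(O)nc-2n1` is the compound still to be measured. It differs from compound 2 by one change: pentyl in place of hydrogen on a saturated chain carbon, six bonds along the chain from an aromatic carbon. The chain on the shared core thus grows from hexyl to undecyl while the rest of the structure stays the same.

For the measured compounds named here, with no measured step to lean on, the expectation rests on the fact that all three compounds shown sit at limits. A modest move toward a lower value is expected, yet still with a fair chance that the assay again reports only a limit. For compound 4 the expected step is an at least 2.0-fold lower number from compound 2 to compound 4 (0.30 log units; that floor lies within the scatter). The estimate for compound 4 is 100000 nM, with a range from 20000 nM to 400000 nM.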

Compound 4, half-maximal cytotoxic concentration: 41000 nM
The estimate for compound 4 lay 2.4-fold (0.39 log units) above the measured number, and the stated range covers the measured number.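

Compound 4 is the first compound shown that gives a readable number rather than a limit in this assay, so a cytotoxic concentration can now be read for this family. Putting pentyl in place of hydrogen on a saturated chain carbon, six bonds along the chain from an aromatic carbon, turns hexyl into undecyl and gives an at least 4.8-fold lower number from compound 2 to compound 4 (0.68 log units; beyond the scatter) on the shared core, a change in chain length alone that lies beyond the usual scatter. The true size of this step is open-ended, and it can be stated only as a floor because compound 2 stands at a limit: the limit of > 200000 nM in this assay, at which 2 of the 4 values shown sit.

From the compounds shown here alone, with only hexyl and undecyl compared on this core, it remains unknown whether the tolerated concentration falls gradually with length or drops sharply somewhere along the way, as an octyl chain in between or a longer tetradecyl chain could reveal. It is also unknown whether the length of the chain alone matters, a question that an undecyl chain ending in an amine or a carboxylic acid would help to settle.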